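Swapping the amine substituent in a tryptamine-piperidine series

The source may hold more compounds than are shown below. What is called first, only, known or untested is meant among the compounds shown, and "the series" means these compounds.

Compound 1 `COC[C@H](NC1CCN(CCCc2c[nH]c3ccc(-n4cnnc4)cc23)CC1)c1ccccc1`: 0.9 nM
Compound 2 `C[C@@H](NC1CCN(CCCc2c[nH]c3ccc(-n4cnnc4)cc23)CC1)c1ccccc1`: 13 nM
Compound 3 `NC(=O)OC[C@H](NC1CCN(CCCc2c[nH]c3ccc(-n4cnnc4)cc23)CC1)c1ccccc1`: 9.3 nM

In an assay on CHO cells for agonist activity at 5-hydroxytryptamine receptor 1D (Homo sapiens), read by GTPgammaS binding (on this read-out higher numbers stand for an effect only at larger amounts of compound and lower numbers for an effect already at smaller amounts), compound 3 stands second highest of the three numbers, within the scatter of compound 2 and well apart from compound 1, as the step of a 10-fold higher number from compound 1 to compound 3 (1.01 log units; beyond the scatter) shows. Compound 4 `CC(=O)Nc1ccc(CNC2CCN(CCCc3c[nH]c4ccc(-n5cnnc5)cc34)CC2)cc1` differs from it by 4-acetamidobenzyl in place of 2-(carbamoyloxy)-1-phenylethyl on an amine nitrogen. Going by the values given here, no measured step matches this change; the nearest are a 14-fold higher number from compound 1 to compound 2 (1.16 log units; beyond the scatter) and a 10-fold higher number from compound 1 to compound 3 (1.01 log units; beyond the scatter), both large, while a 1.4-fold lower number from compound 2 to compound 3 (0.15 log units; within the scatter) is within the scatter. Since changes on this amine nitrogen have moved this assay strongly only away from compound 1, compound 4 is expected near compounds 2 and 3, with a step of a 1.6-fold higher number from compound 3 to compound 4 (0.21 log units; within the scatter). Compound 4 is therefore estimated at 15 nM, between 4 nM and 60 nM.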

Compound 4, half-maximal effective concentration: 5 nM
Compound 4: the middle estimate sits 3.0-fold (0.48 log units) above what was measured; measured number inside the range.
By their numbers in this assay, from the lowest: compound 1; then compounds 4, 3 and 2 (each within the scatter of the next, the first and the last beyond it).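

In this assay, 4-acetamidobenzyl, which has no defined stereocentre, sits on this amine nitrogen with little change against 2-(carbamoyloxy)-1-phenylethyl (a 1.9-fold lower number from compound 3 to compound 4 (0.27 log units; within the scatter)) and a modest gain over 1-phenylethyl (a 2.6-fold lower number from compound 2 to compound 4 (0.41 log units; beyond the scatter)). Even so, 2-methoxy-1-phenylethyl keeps the lowest number of the four (a 5.6-fold higher number from compound 1 to compound 4 (0.74 log units; beyond the scatter)). Nothing available accounts for these differences. Open, as far as these compounds go, is what the acetamido part itself contributes, which plain benzyl, 4-aminobenzyl or 4-carboxybenzyl on this nitrogen would separate. Also open, from the compounds shown here alone, is whether the mirror-image 2-methoxy-1-phenylethyl group would match the number of compound 1.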